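The source may hold more compounds than are shown below. What is called first, only, known or untested is meant among the compounds shown, and "the series" means these compounds.

Measured so far:
compound 1, `CCS(=O)(=O)Nc1ccc(NC(=O)c2ccc(Cl)c([N+](=O)[O-])c2)cc1OC`, 63700 nM;
compound 2, `COc1cc(NC(=O)c2ccc(Cl)c([N+](=O)[O-])c2)ccc1NS(=O)(=O)C(F)(F)F`, > 250000 nM;
compound 3, `CCS(=O)(=O)Nc1ccc(NC(=O)c2ccc(Cl)cc2)cc1F`, 53400 nM.

In an ADME assay on HEK293 cells (Homo sapiens) for cytotoxicity, read by MTT assay, with a stated time of 48 h (on this read-out lower numbers stand for stronger inhibition and higher numbers for weaker inhibition), compound 1 gives 63700 nM. For compound 2 the value > 250000 nM is a limit of the assay, not a number. The change between them is trifluoromethyl in place of ethyl on a sulfonyl sulfur, and it made a step of an at least 3.9-fold higher number from compound 1 to compound 2 (0.59 log units; beyond the scatter); this rests on (the limit of > 250000 nM in this assay, at which 1 of the 3 values shown sits). Compound 3 gives 53400 nM, a value within the scatter of compound 1. The difference between the cores of compound 1 and compound 3 is not broken down here.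

Compound 4, `O=C(Nc1ccc(NS(=O)(=O)C(F)(F)F)c(F)c1)c1ccc(Cl)cc1`, is not yet measured. It differs from compound 3 by trifluoromethyl in place of ethyl on a sulfonyl sulfur, the same change as from compound 1 to compound 2. Compound 4 is therefore expected to show a step of a 4.1-fold higher number from compound 3 to compound 4 (0.61 log units; beyond the scatter), a weaker-inhibition move like an at least 3.9-fold higher number from compound 1 to compound 2 (0.59 log units; beyond the scatter). The estimate for compound 4 is 220000 nM, between 100000 nM and 500000 nM, with a real chance that only a limit is reported.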

Compound 4, half-maximal inhibitory concentration: 79000 nM
The estimate for compound 4 lay 2.8-fold (0.44 log units) above the measured number; the measured number lies below the stated range.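

In this assay, trifluoromethyl in place of ethyl on a sulfonyl sulfur gives a 1.5-fold higher number from compound 3 to compound 4 (0.17 log units; within the scatter), so on the core of compound 3 the change does not move the number beyond the scatter. For compound 2, the reading of > 250000 nM is a limit of the assay and not a number. The step therefore cannot be shown either to carry over unchanged from one core to the other or to depend on the core: the same change on two cores in this assay, an at least 3.9-fold higher number (0.59 log units; beyond the scatter) from compound 1 to compound 2 and a 1.5-fold higher number (0.17 log units; within the scatter) from compound 3 to compound 4; the limit leaves it open whether they differ.

The compounds shown do not separate the nitro group from the methoxy and fluorine difference as the part of the core that might matter. They also leave open how a longer alkyl chain or an amine on the sulfonyl sulfur would read.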